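The source may hold more compounds than are shown below. What is called first, only, known or untested is meant among the compounds shown, and "the series" means these compounds.

Measured in an ADME assay on BCBL1 cells (Homo sapiens) for cytotoxicity, with a stated time of 7 days; on this read-out higher numbers stand for lower toxicity in this test and lower numbers for higher toxicity in this test:
- compound 1 `COCCOc1nc(N)nc2c1ncn2/C=C1/CC1(CO)CO`: > 20000 nM (a limit)
- compound 2 `Nc1nc(OCc2ccccc2)c2ncn(/C=C3/CC3(CO)CO)c2n1`: > 20000 nM (a limit)
- compound 3 `Nc1nc(NCc2ccccc2)c2ncn(/C=C3/CC3(CO)CO)c2n1`: 19900 nM

Compound 1 has no exact figure, only the reading > 20000 nM, which is a limit of this assay. The series is crowded against (the limit of > 20000 nM in this assay, at which 2 of the 3 values shown sit).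

Compound 4 `CC(C)Nc1nc(N)nc2c1ncn2/C=C1/CC1(CO)CO` has not yet been measured. It carries isopropylamino in place of the 2-methoxyethoxy of compound 1 on an aromatic carbon: isopropylamino in place of 2-methoxyethoxy on an aromatic carbon.

The closest measured change also puts an amino group in place of that 2-methoxyethoxy, and it gives a number no higher from compound 1 to compound 3 (the limit leaves the size open). The change from an oxygen-bound to a nitrogen-bound benzyl group gives a number no higher from compound 2 to compound 3 (the limit leaves the size open). Neither step has a readable size, and a step that the two limits leave unreadable from compound 1 to compound 2 adds no size either. Within the data shown here, the one exact figure comes from compound 3, with 19900 nM, and it is the only amino-bearing compound measured so far. No step beyond the usual scatter is therefore expected, and the estimated change is a number no higher from compound 1 to compound 4 (the limit leaves the size open). A reading at the limit would be no surprise.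

For compound 4 the expected value is 20000 nM, with an estimated range from 8000 nM to 50000 nM.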

Compound 4, half-maximal cytotoxic concentration: > 20000 nM
Compound 4: no number, only a limit; the forecaster's own chance of this, stated with the estimate: 55%; the middle value lies on the limit itself.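

In this assay compound 4 gives > 20000 nM, which is a limit and not a number. It is thus a second amino-bearing compound at this aromatic carbon, and it shows that such a group need not bring the reading inside the measurable range, a point that compound 3 alone could not settle; isopropyl in place of benzyl on that nitrogen gives a number no lower from compound 3 to compound 4 (the limit leaves the size open). With this result, the series is pressed still harder against the top of the test: the limit of > 20000 nM in this assay, at which 3 of the 4 values shown sit.

The steps from compound 1 and from compound 2 to compound 4 cannot be read, as both ends of each are limits, so the compounds shown do not tell how isopropylamino compares with 2-methoxyethoxy or benzyloxy at this place. On these data alone, it also remains open whether a dimethylamino group, a cyclopropylamino group or a longer chain on that nitrogen would give an exact figure in this assay, and whether benzylamino stands apart from the other groups or only happens to fall just inside the limit.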